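Working notes on the shared core: removal of the benzyl phenyl

The compounds below may be only part of what the source reports. "The series", "measured", "known", "first", "only" and "open" are said of these compounds alone.

Measured compounds:
- compound 1, `C=CCn1ncc2cnc(Cc3ccccc3)n2c1=O`: > 48000 nM in a functional assay for inhibition, with Homo sapiens as the target; a higher number here means a weaker inhibitor, a lower number a stronger inhibitor (a limit)
- compound 2, `Cn1ncc2cnc(Cc3ccccc3)n2c1=O`: > 48000 nM (a limit)
- compound 3, `C=CCn1ncc2c(C)nc(Cc3ccccc3)n2c1=O`: > 48000 nM (a limit)

Compound 1 stands only at a limit of this assay, not at a number. The same holds for compound 2 and for compound 3, so every value shown in this series is the limit of > 48000 nM in this assay, at which 3 of the 3 values shown sit. The two steps that start from compound 1 are therefore unreadable: a step that the two limits leave unreadable from compound 1 to compound 2 and a step that the two limits leave unreadable from compound 1 to compound 3 give no size in either direction.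

The step to compound 4, `C=CCn1ncc2cnc(C)n2c1=O`, is hydrogen in place of phenyl on a saturated chain carbon bound to an aromatic carbon. Within the data shown here, no measured step bears on this change; the two steps that are known touch the saturated chain carbon bound to an aromatic nitrogen and an aromatic carbon of the core, and both leave only a limit at each end. With nothing read out above the limit anywhere in the series, no step beyond the scatter can be expected in this assay for compound 4; the expected step of a number no higher from compound 1 to compound 4 (the limit leaves the size open) is essentially none. Compound 4 is therefore estimated at 48000 nM in this assay, with a range from 20000 nM to 200000 nM, and most likely the assay again reports only a limit.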

Compound 4, half-maximal inhibitory concentration: > 48000 nM
Compound 4: only a limit was reported (the forecaster's own chance of this, stated with the estimate: 90%); the middle value sits exactly at the limit.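

Compound 1 and compound 4 both stand only at a limit in this assay, so no step can be read for hydrogen in place of phenyl on a saturated chain carbon bound to an aromatic carbon. The compounds shown leave open whether any change on the shared core gives a readable number, and the series still rests at a single value: the limit of > 48000 nM in this assay, at which 4 of the 4 values shown sit.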